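A few compounds are considered here, and "the series" means these few. Any claim that something is new, unique, unknown or untested is made for them only; others in the source may bear on it.

Measured so far, in a functional assay on P388 cells (Mus musculus) for inhibition; on this read-out higher numbers stand for weaker inhibition and lower numbers for stronger inhibition: compound 1 `O=C1/C(=C/c2ccc(Br)cc2)CCc2ccccc21` gives 20400 nM; compound 2 `Cc1ccc(/C=C2\CCc3ccccc3C2=O)cc1` gives 17700 nM; compound 3 `O=C1/C(=C/c2cccc(Br)c2)CCCc2ccccc21` gives 10500 nM.

Compound 1 and compound 2 share a core and differ by methyl in place of bromo on an aromatic carbon. This change made a 1.2-fold lower number from compound 1 to compound 2 (0.06 log units; within the scatter). Compound 3 rests on a different core; the difference between the two cores is not broken down here. Compound 4 `Cc1cccc(/C=C2\CCCc3ccccc3C2=O)c1`, not yet measured, differs from compound 3 by methyl in place of bromo on an aromatic carbon. Among the measured compounds shown here, it is the same kind of change as the one from compound 1 to compound 2, though the place is not identical: there the methyl sits para to a large group, here meta to a large group.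

Because the earlier step was a 1.2-fold lower number from compound 1 to compound 2 (0.06 log units; within the scatter), a step of similar size is expected for compound 4, so for compound 4 the expected step is a 1.2-fold lower number from compound 3 to compound 4 (0.07 log units; within the scatter). Compound 4 is therefore estimated at 9000 nM, between 4500 nM and 18000 nM.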

Compound 4, half-maximal inhibitory concentration: 19900 nM
Compound 4: middle estimate off by 2.2-fold (0.34 log units), on the low side; the whole stated range lies below it.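

In this assay, putting methyl in place of bromo on the aromatic ring gave a 1.9-fold higher number from compound 3 to compound 4 (0.28 log units; within the scatter). Set beside the earlier swap, this step gives no sign that the core alters the effect of the change: the same change on two cores in this assay, a 1.2-fold lower number (0.06 log units; within the scatter) from compound 1 to compound 2 and a 1.9-fold higher number (0.28 log units; within the scatter) from compound 3 to compound 4, 2.2-fold (0.34 log units) apart, within the scatter of two such steps. Among the compounds shown here, this does not show that the change behaves identically on every core, as there are only two steps, both small, and the group sits at a different place on the ring in each pair.

The compounds shown leave open what a clearly different group on this ring, such as an amine or a carboxylic acid, would do. They also leave open whether moving the methyl or bromo on a single core would matter.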